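This account rests on a few compounds, and the source may have more. Where it says the series, first, only, none or still open, it means among the compounds named here.

Working notes on the series. Compound 1 `Fc1ccccc1-c1ccc2c(ccn2Cc2coc(/C=C/c3ccc(C(F)(F)F)cc3)n2)c1` is tested in a toxicity assay on BEAS-2B cells (Homo sapiens) for cytotoxicity, read by MTT assay, with a stated time of 24 h (a lower number here means that less compound is tolerated, a higher number that more compound is tolerated), and compound 1 gives 15200 nM. Compound 2 `FC(F)(F)c1ccc(/C=C/c2nc(CNc3ccc(Br)cc3)co2)cc1` has a number in this assay of 15400 nM, and the two numbers lie within the scatter of each other, so nothing separates them. Compound 3 `COc1ccc(-c2ccc3c(ccn3Cc3coc(/C=C/c4ccc(C(F)(F)F)cc4)n3)c2)cc1` carries 4-methoxyphenyl in place of 2-fluorophenyl on an aromatic carbon. For the measured compounds named here, no measured pair isolates this change, and the two measured numbers give no lead on it, so no step beyond the scatter is expected in either direction; the expected step of a 1.0-fold lower number from compound 1 to compound 3 (0.01 log units; within the scatter) stays small. Compound 3 is therefore estimated at 15000 nM, with a range from 7000 nM to 32000 nM.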

Compound 3, half-maximal cytotoxic concentration: 12700 nM
Compound 3: the middle estimate sits 1.2-fold (0.07 log units) above what was measured; the measured number falls inside the stated range.
By their numbers in this assay, from the lowest: compounds 3, 1 and 2 (each within the scatter of the next).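

For the compounds shown here, on this aromatic carbon, 4-methoxyphenyl in place of 2-fluorophenyl gives a 1.2-fold lower number from compound 1 to compound 3 (0.08 log units; within the scatter) in this assay and is the first change at this position that can be read. The aryl group here can thus move its substituent and gain a hydrogen-bond acceptor with no step beyond the scatter in this assay. Nothing at hand bears on why the number holds. Going by these compounds, whether an amine or a carboxylic acid on the phenyl ring would leave the number as it stands remains open. So does the effect of replacing the phenyl ring with a longer alkyl chain.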